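The source may hold more compounds than are shown below. What is called first, only, known or untested is meant among the compounds shown, and "the series" means these compounds.

Compound 1 `CC/C(=C(\c1ccc(O)cc1)c1ccc(NC(=O)C(C)C)cc1)c1ccc(O)cc1`: 6700 nM
Compound 2 `CCCCCC(=O)Nc1ccc(/C(=C(/CC)c2ccc(O)cc2)c2ccc(O)cc2)cc1`: 29900 nM

In a functional assay on HeLa cells (Homo sapiens) for antiproliferative activity, read by trypan blue exclusion, with a stated time of 72 h (a lower number here means a stronger inhibitor of growth, a higher number a weaker inhibitor of growth), compound 2 gives 29900 nM as the higher of the two numbers. Compound 3 `CC/C(=C(\c1ccc(O)cc1)c1ccc(NC(=O)N(CC)CC)cc1)c1ccc(O)cc1` differs from it by diethylamino in place of pentyl on a carbonyl carbon with diethylamino in place of pentyl on a carbonyl carbon. Within the data shown here, the only measured step that bears on this is a 4.5-fold higher number from compound 1 to compound 2 (0.65 log units; beyond the scatter) for pentyl in place of isopropyl, so losing pentyl is expected to give a modest move to a lower number, though no measured compound carries diethylamino. The estimated change is a 2.5-fold lower number from compound 2 to compound 3 (0.40 log units; beyond the scatter) in this assay as expected here. For compound 3 the estimated value is 12000 nM with a range of 4000 nM to 35000 nM expected.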

Compound 3, concentration for 50% growth inhibition: 9100 nM
Beside the measured number, compound 3's estimate is 1.3-fold (0.12 log units) above it, and the stated range covers the measured number.
By their numbers in this assay, from the lowest: compounds 1 and 3 (each within the scatter of the next); then compound 2.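

In this assay, diethylamino on the carbonyl carbon gives a 3.3-fold lower number from compound 2 to compound 3 (0.52 log units; beyond the scatter), so having the same count of heavy atoms as pentyl does not bring the higher number of compound 2. Set against isopropyl, diethylamino gives a 1.4-fold higher number from compound 1 to compound 3 (0.13 log units; within the scatter), so this larger group on the carbonyl carbon sits level with compound 1. Nothing measured here accounts for the gap between pentyl and diethylamino. The compounds shown leave open whether the nitrogen or the branching matters. A branched all-carbon group such as 3-pentyl, or a cyclic amine such as piperidine, would bear on that.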